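Fluorine removal on a phenyl ring: cytotoxicity unchanged?

The compounds below may be only part of what the source reports. "The series", "measured", "known", "first", "only" and "open" are said of these compounds alone.

Measured so far:
compound 1 `O=C(Nc1ccc2sc(-c3ccccc3F)nc2c1)N1CCCC1`, > 50 uM
compound 2 `O=C(Nc1ccc2sc(-c3ccc(F)c(F)c3)nc2c1)N1CCCCC1`, > 50 uM
compound 3 `O=C(Nc1ccc2sc(-c3ccccc3)nc2c1)N1CCCC1`, > 50 uM

All three were tested in an ADME assay on HepG2 cells (Homo sapiens) for inhibition, read by resazurin assay, with a stated time of 48 h; a lower number here means that less compound is needed, a higher number that more compound is needed for the effect. Compound 1 gives > 50 uM, which is a limit of the assay rather than a number. Compound 2 likewise gives > 50 uM, again a limit. Compound 3 gives > 50 uM, also a limit. From compound 1 to compound 3 the change is hydrogen in place of fluoro on an aromatic carbon, and the step it made is a step that the two limits leave unreadable from compound 1 to compound 3, since both ends sit at the limit of > 50 uM in this assay, at which 3 of the 3 values shown sit.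

Compound 4 `O=C(Nc1ccc2sc(-c3ccc(F)cc3)nc2c1)N1CCCCC1` is not yet measured. It differs from compound 2 by hydrogen in place of fluoro on an aromatic carbon. The difference between the cores of compound 1 and compound 2 is not broken down here. The two changes are the same kind of change but not the same: in compound 1 the departing fluoro sits ortho to a large group, whereas in compound 2 it sits ortho to a fluoro group (1 heavy atom) and meta to a large group.

In this assay the step expected is a step that the limit leaves unreadable from compound 2 to compound 4, which rests on compound 1 and compound 3 both sitting at the limit of > 50 uM in this assay, at which 3 of the 3 values shown sit, and on compound 2 giving > 50 uM. For compound 4 the estimate is 70 uM, most likely reported as a limit again, with a plausible range from 25 uM to 200 uM.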

Compound 4, concentration for 90% of the maximal effect: > 50 uM
Compound 4 was reported as a limit; the forecaster's own chance of this, stated with the estimate: 80%; the middle value lies beyond the limit too.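

In this assay compound 4 gives > 50 uM, which is a limit of the assay and not a number. No size can be read for the change from compound 2 to compound 4, since both sit at the same limit: the limit of > 50 uM in this assay, at which 4 of the 4 values shown sit.

The compounds shown leave open at what concentration any of them reaches the effect in this assay, and so whether hydrogen in place of fluoro changes it at all.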